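Aryl change on the amide from compound 3 to compound 4

The source may report more compounds than this note shows. Statements on the series, on what has been measured and on what is new or still open speak of the compounds shown alone.

In a functional assay on NCI-H1299 cells (Homo sapiens) for inhibition, read by CCK-8 assay, with a stated time of 72 h, tested at 10 uM (on this read-out lower numbers stand for less inhibition of growth and higher numbers for more inhibition of growth at the one concentration tested), compound 3 (`CN(C)C(=O)c1cc2cnc(Nc3ccc(NC(=O)C4(C(=O)Nc5ccccc5F)CC4)cc3)nc2n1C1CCCC1`) gives 89.6% at the one concentration tested. This lies within the scatter of compound 1 (`CN(C)C(=O)c1cc2cnc(Nc3ccc(N)cn3)nc2n1C1CCCC1`), which gives 82.1% in the same test. It lies beyond the scatter of compound 2 (`CN(C)C(=O)c1cc2cnc(Nc3ccc(NC(=O)C4(C(=O)Nc5cccc(O)c5)CC4)cc3)nc2n1C1CCCC1`), which gives 78.5% and sits lower.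

The next change leads to compound 4 (`CN(C)C(=O)c1cc2cnc(Nc3ccc(NC(=O)C4(C(=O)Nc5cccc(Br)c5)CC4)cc3)nc2n1C1CCCC1`), with 3-bromophenyl in place of 2-fluorophenyl on an amide-type nitrogen. Within the data shown here, one measured step bears on this place: a number 11.1 percentage points higher from compound 2 to compound 3 (beyond the scatter) for 2-fluorophenyl in place of 3-hydroxyphenyl. Among the measured compounds shown here, that step is modest, and no measured compound carries 3-bromophenyl, so the direction is only weakly supported. Compound 1 lacks this amide side altogether and gives no guide to the swap. A reading inside the span from compound 2 (78.5%) to compound 3 (89.6%) is expected, which means a slight fall at most and no step beyond the scatter. The expected change in this assay is small (a number 5.6 percentage points lower from compound 3 to compound 4 (within the scatter)). For compound 4 the estimate is 84% (expected range 72% to 93%).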

Compound 4, percent growth inhibition at one concentration: 77.5%
Estimate against measurement, compound 4: 6.5 percentage points above, and the stated range covers the measured number.
By their numbers in this assay, from the lowest: compounds 4, 2, 1 and 3 (each within the scatter of the next, the first and the last beyond it).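

In this assay, the aryl group on the amide-type nitrogen can move the reading down as well as up: the earlier a number 11.1 percentage points higher from compound 2 to compound 3 (beyond the scatter) showed only a rise, whereas 3-bromophenyl in place of 2-fluorophenyl gives a number 12.1 percentage points lower from compound 3 to compound 4 (beyond the scatter) and is also beyond the scatter. Bromo in place of hydroxy on an aromatic carbon gives a number 1 percentage points lower from compound 2 to compound 4 (within the scatter) within the scatter, so 3-bromophenyl and 3-hydroxyphenyl read alike here, and among the three amide compounds only compound 3, with 2-fluorophenyl, stands apart from compound 4. No measurement at hand accounts for the fall from the 2-fluorophenyl compound to the 3-bromophenyl compound.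

The step from compound 3 to compound 4 changes both the halogen and its place on the ring, so the two contributions remain unseparated, and a 3-fluorophenyl or 2-bromophenyl group on the same nitrogen would pull them apart. Also open, on these data alone, is whether an aromatic ring is needed there at all, a question that a cyclohexyl group or a short alkyl chain on that nitrogen would address.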